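Lengthening the Amine Chain in a Cytotoxicity Series

This account rests on a few compounds, and the source may have more. Where it says the series, first, only, none or still open, it means among the compounds named here.

Compound 1 `CN(C)CCNc1ccnc2cc(OCc3ccccc3)ccc12`: 1620 nM
Compound 2 `C=CCOc1ccc2c(NCCN(C)C)ccnc2c1`: 930 nM
Compound 3 `CCCCCCOc1ccc2c(NCCN(C)C)ccnc2c1`: 930 nM

In a functional assay on NCI-H1650 cells (Homo sapiens) for cytotoxicity, read by MTT assay, with a stated time of 48 h (a lower number here means a stronger inhibitor, a higher number a weaker inhibitor), compound 2 gives 930 nM, level with compound 3 at the digits shown, the two together being the lowest of the three numbers. The steps of a 1.7-fold lower number from compound 1 to compound 2 (0.24 log units; within the scatter) and no change at the digits printed from compound 2 to compound 3 (within the scatter) both lie within the scatter, as does a 1.7-fold lower number from compound 1 to compound 3 (0.24 log units; within the scatter). Compound 4 `C=CCOc1ccc2c(NCCCN(C)C)ccnc2c1` differs from compound 2 in one place: (dimethylamino)methyl in place of dimethylamino on a saturated chain carbon, two bonds along the chain from a nitrogen on an aromatic ring. Within the data shown here, every measured step alters the group attached to the oxygen on the shared core; none touches the amine chain, so no measured step bears directly on this change. Without such guidance, a step no larger than the scatter is expected: no change at the digits printed from compound 2 to compound 4 (within the scatter). Compound 4 is therefore expected to give about 930 nM, within a range from 300 nM to 2900 nM.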

Compound 4, half-maximal inhibitory concentration: 3120 nM
Beside the measured number, compound 4's estimate is 3.4-fold (0.53 log units) below it, and the stated range ends below it.
By their numbers in this assay, from the lowest: compounds 2, 3, 1 and 4 (each within the scatter of the next, the first and the last beyond it).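

Lengthening the amine chain, with (dimethylamino)methyl in place of dimethylamino on a saturated chain carbon, gives in this assay a 3.4-fold higher number from compound 2 to compound 4 (0.53 log units; beyond the scatter). Among these compounds, this is the only step beyond the scatter, so the amine chain registers a difference that the changes to the group on the oxygen did not. Nothing shown here gives a reason for this step. From the compounds shown here alone, it remains open whether a still longer chain, such as 4-(dimethylamino)butyl, or a diethylamino end would move the number further. Going by these compounds, the same chain change also remains untested alongside the groups on the oxygen of compound 1 and compound 3.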